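A few compounds are considered here, and "the series" means these few. Any claim that something is new, unique, unknown or untested is made for them only; others in the source may bear on it.

Compound 1 `COc1cccc(/C=C2\CCC/C(=C\c3ccccc3Cl)C2=O)c1OC`: in a functional assay on MCF7 cells (Homo sapiens) for cytotoxicity, read by MTT assay, with a stated time of 72 h (on this read-out lower numbers stand for stronger inhibition and higher numbers for weaker inhibition), compound 1 gives 11300 nM.
Compound 2 `COc1cccc(/C=C2\CCC/C(=C\c3ccc(Br)cc3)C2=O)c1OC`: in this assay compound 2 gives 13800 nM.
Compound 3 `COc1cccc(/C=C2\CCC/C(=C\c3cccc(Cl)c3Cl)C2=O)c1OC`: in this assay compound 3 reaches only a limit of the assay, > 20000 nM (the limit of > 20000 nM in this assay, at which 1 of the 3 values shown sits).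

Among the two numbers, compound 1 stands lowest; the nearest value is a 1.2-fold higher number from compound 1 to compound 2 (0.09 log units; within the scatter). Compound 4 `COc1cccc(/C=C2\CCC/C(=C\c3ccc(Cl)cc3Cl)C2=O)c1OC` differs from compound 1 by chloro in place of hydrogen on an aromatic carbon, which read one bond further out is 2-chlorophenyl to 2,4-dichlorophenyl. One measured step is of the same kind, chloro in place of hydrogen on the same ring: an at least 1.7-fold higher number from compound 1 to compound 3 (0.24 log units; that floor lies within the scatter), ending at a limit. A shift of similar character is therefore expected in this assay, a 1.5-fold higher number from compound 1 to compound 4 (0.18 log units; within the scatter), towards a higher number, with its floor inside the scatter. Compound 4 is estimated at 17000 nM, expected between 8000 nM and 40000 nM.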

Compound 4, half-maximal inhibitory concentration: > 20000 nM
Compound 4 gave a limit, no number; the forecaster's own chance of this, stated with the estimate: 35%; middle value at least 1.1-fold (0.07 log units) away from the limit.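

Chloro placed on the ring of compound 1, meta to its chloro group and para to a large group, gives an at least 1.7-fold higher number from compound 1 to compound 4 (0.24 log units; that floor lies within the scatter). The 2,4-dichlorophenyl group set against the 4-bromophenyl group gives an at least 1.4-fold higher number from compound 2 to compound 4 (0.16 log units; that floor lies within the scatter). The step between the two dichlorophenyl compounds, compound 3 and compound 4, cannot be read, so these two chloro places are not told apart, and both compounds now stand at a limit: the limit of > 20000 nM in this assay, at which 2 of the 4 values shown sit.

Going by these compounds, how far the true values of compound 3 and compound 4 lie from that limit remains open. Also open, on these data alone, is whether an amine or a carboxylic acid at this place on the ring would give a lower number.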